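Para-halogen swap on a benzamide of a hexafluoro-carbinol naphthalene

This account rests on a few compounds, and the source may have more. Where it says the series, first, only, none or still open, it means among the compounds named here.

In an assay on LtK cells with ATP-sensitive inward rectifier potassium channel 11 (Homo sapiens) as the target (on this read-out higher numbers stand for an effect only at larger amounts of compound and lower numbers for an effect already at smaller amounts), two compounds sharing the same core have been measured. Compound 1 `O=C(Nc1c(C(O)(C(F)(F)F)C(F)(F)F)ccc2ccccc12)c1ccccc1Cl` gives 2040 nM. For the measured compounds named here, compound 2 `O=C(Nc1c(C(O)(C(F)(F)F)C(F)(F)F)ccc2ccccc12)c1ccc(Cl)cc1` gives 570 nM, the lowest of the two numbers, and the only step recorded, a 3.6-fold lower number from compound 1 to compound 2 (0.55 log units; beyond the scatter), moves the chloro from one position of the benzamide ring to another. Compound 3 `O=C(Nc1c(C(O)(C(F)(F)F)C(F)(F)F)ccc2ccccc12)c1ccc(I)cc1` is not yet measured; it differs from compound 2 by iodo in place of chloro on an aromatic carbon. Going by the values given here, no measured step bears directly on this change: the single recorded step concerns where the chloro sits, not which halogen occupies that place, so it offers only a loose guide to how much a change at the same position can matter. On the numbers at hand, one halogen for another at the same carbon is expected to give at most a small shift, and compound 3 is estimated at 450 nM, with a range from 150 nM to 1500 nM. The step this implies, a 1.3-fold lower number from compound 2 to compound 3 (0.10 log units; within the scatter), is expected to stay close to the scatter.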

Compound 3, half-maximal effective concentration: 154 nM
Compound 3: middle estimate off by 2.9-fold (0.47 log units), on the high side; the range from low to high includes it.
By their numbers in this assay, from the lowest: compound 3; then compound 2; then compound 1.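

In this assay, the change of chloro to iodo on this aromatic carbon, para to a large group, gives a 3.7-fold lower number from compound 2 to compound 3 (0.57 log units; beyond the scatter) and so shows that the identity of the halogen matters here, not only where a chloro sits on the ring. Taken with the earlier move of the chloro, the full change from 2-chlorophenyl to 4-iodophenyl gives a 13-fold lower number from compound 1 to compound 3 (1.12 log units; beyond the scatter) and places compound 3 lowest of the three, with its steps to both other compounds beyond the scatter. No measurement available here accounts for the lower number with iodo than with chloro.

The compounds shown leave open whether bromo or fluoro on the same carbon would read close to chloro, close to iodo or elsewhere, as two halogens at one carbon do not make a trend. They also leave open how a non-halogen group there, such as methoxy or an amine, would read, and whether iodo in the place held by the chloro of compound 1 would give a higher number than iodo in compound 3.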